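This account rests on a few compounds, and the source may have more. Where it says the series, first, only, none or still open, it means among the compounds named here.

Compound 2 `COc1cc(-c2nn(-c3cccc(NC(=O)Nc4ccc(Cl)c(C(F)(F)F)c4)c3)cc2-c2ccncc2)ccc1Cl` stands at the lower of the two numbers measured in a functional assay on LOX IMVI cells (Homo sapiens) for inhibition, read by sulforhodamine B assay, with a stated time of 48 h (a higher number here means a weaker inhibitor of growth, a lower number a stronger inhibitor of growth), where compound 2 gives 1170 nM. Its neighbour compound 1 `COc1cc(-c2nn(-c3cccc(NC(=O)c4ccc(Cl)c(C(F)(F)F)c4)c3)cc2-c2ccncc2)ccc1Cl` gives 1920 nM in this assay, and the step of a 1.6-fold lower number from compound 1 to compound 2 (0.22 log units; within the scatter) is within the scatter. Compound 3 `COc1cc(-c2nn(-c3cccc(NC(=O)c4ccccc4)c3)cc2-c2ccncc2)ccc1Cl` differs from compound 2 by phenyl in place of (4-chloro-3-(trifluoromethyl)phenyl)amino on a carbonyl carbon. Among the measured compounds shown here, only one measured step bears on this change: the step from compound 1 to compound 2 touched the same carbonyl carbon, exchanging an aryl for an arylamino group, and it was small. For the measured compounds named here, no measured step speaks to the loss of the chloro and trifluoromethyl groups, which is the larger part of the change to compound 3. The expected step of a 3.2-fold higher number from compound 2 to compound 3 (0.51 log units; beyond the scatter) is therefore towards a higher number, with wide uncertainty. Compound 3 is estimated at 3800 nM in this assay, within a range of 1300 nM to 11000 nM.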

Compound 3, concentration for 50% growth inhibition: 567 nM
The estimate for compound 3 lay 6.7-fold (0.83 log units) above the measured number, outside the stated range (below it).
By their numbers in this assay, from the lowest: compound 3; then compounds 2 and 1 (each within the scatter of the next).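

In this assay, the earlier step on this carbonyl carbon, exchanging an aryl for an arylamino group, stayed within the scatter, whereas the plain phenyl of compound 3 gives a clear change: a 2.1-fold lower number from compound 2 to compound 3 (0.31 log units; beyond the scatter) and a 3.4-fold lower number from compound 1 to compound 3 (0.53 log units; beyond the scatter). Among these three compounds, the 4-chloro-3-(trifluoromethyl)phenyl group, whether bound directly or through its amino link, is therefore not needed for growth inhibition in this assay, and compound 3, with the unsubstituted phenyl, has the lowest number. No available evidence accounts for this result.

The compounds shown do not separate the contributions of the chloro and trifluoromethyl groups, since both leave together. From the compounds shown here alone, it also remains open how a phenylamino group with no substituents, a phenyl carrying chloro alone or trifluoromethyl alone, or a methyl on the carbonyl carbon would compare.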